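A few compounds are considered here, and "the series" means these few. Any claim that something is new, unique, unknown or untested is made for them only; others in the source may bear on it.

Measured in a functional assay on T47D cells (Homo sapiens) for inhibition, read by sulforhodamine B assay, with a stated time of 48 h; a higher number here means a weaker inhibitor of growth, a lower number a stronger inhibitor of growth:
- compound 1 `Cc1cc(=O)oc2cc(N=C=[Se])ccc12`: 3600 nM
- compound 2 `CCCOC(=[Se])Nc1ccc2c(C)cc(=O)oc2c1`: 41000 nM

Compound 2 holds the higher of the two numbers, beyond the scatter of compound 1, and so is the weaker inhibitor of growth of this pair. Compound 3 `Cc1cc(=O)oc2cc(NC(=[Se])Nc3ccccc3)ccc12` has not yet been measured. It differs from compound 2 by having anilino in place of propoxy on a saturated chain carbon bound to a nitrogen on an aromatic ring. For the measured compounds named here, no measured pair shows the effect of a single change, so any forecast is tentative. Compound 2 at 41000 nM lies well up the scale, while compound 1 at 3600 nM shows that a lower number is reachable on the shared core. A moderate step towards a lower number is therefore expected in this assay, although the outcome may stay within the scatter. The expected change is a 3.4-fold lower number from compound 2 to compound 3 (0.53 log units; beyond the scatter). Compound 3 is estimated at 12000 nM, with an expected range of 3000 nM to 50000 nM.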

Compound 3, concentration for 50% growth inhibition: 24000 nM
Compound 3: the middle estimate sits 2.0-fold (0.30 log units) below what was measured, within the range that was stated.
By their numbers in this assay, from the lowest: compound 1; then compounds 3 and 2 (each within the scatter of the next).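

In this assay, for the compounds shown here, anilino in place of propoxy on a saturated chain carbon bound to a nitrogen on an aromatic ring gives a 1.7-fold lower number from compound 2 to compound 3 (0.23 log units; within the scatter), the first single-place comparison. This place therefore accepts a larger group, carrying a six-membered aromatic ring and a hydrogen-bond donor that propoxy lacks, with no difference in growth inhibition beyond the scatter. Nothing available here bears on why the two compounds read alike.

The compounds shown leave open whether a longer chain such as hexyloxy, or an amine such as morpholine, at this place would shift the number beyond the scatter. Also open, as far as these compounds go, is whether a chlorine atom or a methoxy group on the anilino ring would do so, and whether benzyloxy would read like propoxy or like anilino.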